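This account rests on a few compounds, and the source may have more. Where it says the series, first, only, none or still open, it means among the compounds named here.

In a physicochemical assay for lipophilicity, read by HPLC, at pH 7.4 (a lower number here means a more polar compound, a higher number a more lipophilic compound), compound 1 (`C[C@@H](Oc1cc2cnn(CCC(=O)O)c2cc1Cl)c1ccccn1`) gives 1.7 and compound 2 (`Cc1ccc([C@@H](C)Oc2cc3onc(CCC(=O)O)c3cc2Cl)nc1`) gives 2.42 while compound 3 (`O=C(O)CCn1c(=O)oc2cc(OCC3CCC3)c(Cl)cc21`) gives 2.9 as the highest of these three numbers, with its gaps to both others beyond the usual scatter of repeated measurements.

Compound 4 (`O=C(O)CCn1c(=O)oc2cc(OCc3ccccn3)c(Cl)cc21`) has not been measured yet. It shares the core of compound 3 and differs from it in one place, where pyridin-2-yl in place of cyclobutyl on a saturated chain carbon bound to an oxygen on an aromatic ring is the change on a saturated chain carbon bound to an oxygen on an aromatic ring.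

For the measured compounds named here, no two measured compounds differ in just one place, so there is no measured step to carry over directly. The nearest guide is compound 1, which also carries pyridin-2-yl and reads 1.7 on its own core, although its other differences from compound 3 make this a loose comparison. A fall beyond the scatter is therefore expected rather than shown. An estimated a number 1.10 log units lower from compound 3 to compound 4 (beyond the scatter) would bring the number close to that of compound 1, though the uncertainty remains wide. For compound 4 the estimate is 1.8 with an expected range from 1.4 to 2.2 in this assay once the measurement is available.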

Compound 4, distribution coefficient: 1.32
For compound 4 the middle estimate is 0.48 log units above the measured one; the measured number lies below the stated range.
By their numbers in this assay, from the lowest: compound 4; then compound 1; then compound 2; then compound 3.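

For the compounds shown here, this pair gives the first measured change at a single place in this assay: on the shared core, putting pyridin-2-yl in place of cyclobutyl on a saturated chain carbon bound to an oxygen on an aromatic ring gives a number 1.58 log units lower from compound 3 to compound 4 (beyond the scatter), a large step. The earlier compounds shown here differed in several places at once, so their gaps could not be tied to any one place, whereas this result shows that the group at this position alone can shift the reading strongly. The entering group is aromatic, contains a nitrogen and counts 1 hydrogen-bond acceptor where cyclobutyl counts 0, but nothing shown here establishes which of these features accounts for the step.

From the compounds shown here alone, what stays open is whether the step follows the ring nitrogen or the aromatic ring itself, and a phenyl group at this place on the same core would separate the two. Moving the nitrogen, as in pyridin-3-yl, would test whether its place in the ring matters, and a step on a different core would show whether this change carries over.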